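Amide variation on the shared core: cytotoxicity notes

A few compounds are considered here, and "the series" means these few. Any claim that something is new, unique, unknown or untested is made for them only; others in the source may bear on it.

Measured compounds:
compound 1 `O=C(c1cccc(F)c1)N1CCN(c2nc(=O)c3cc(C(F)(F)F)cc([N+](=O)[O-])c3s2)CC1` gives > 125000 nM in an ADME assay on Vero cells (Chlorocebus sabaeus) for cytotoxicity, read by MTT assay, with a stated time of 72 h (a lower number here means that less compound is tolerated, a higher number that more compound is tolerated), a limit of the assay.
compound 2 `CSCC(=O)N1CCN(c2nc(=O)c3cc(C(F)(F)F)cc([N+](=O)[O-])c3s2)CC1` gives > 125000 nM in this assay, a limit of the assay.
compound 3 `O=C(c1ccc(F)cc1)N1CCN(c2nc(=O)c3cc(C(F)(F)F)cc([N+](=O)[O-])c3s2)CC1` gives > 125000 nM in this assay, a limit of the assay.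

Compound 3 stands at the limit of > 125000 nM in this assay, at which 3 of the 3 values shown sit. The steps a step that the two limits leave unreadable from compound 1 to compound 3, a step that the two limits leave unreadable from compound 2 to compound 3 and a step that the two limits leave unreadable from compound 1 to compound 2 therefore carry no readable size in this assay. Compound 4 `Cc1ccc(C(=O)N2CCN(c3nc(=O)c4cc(C(F)(F)F)cc([N+](=O)[O-])c4s3)CC2)cc1` differs from compound 3 by methyl in place of fluoro on an aromatic carbon. Among the measured compounds shown here, no measured step bears directly on this change; what the three amides show is only that each sits at the limit. Compound 4 is accordingly expected to sit at the limit as well, estimated at 150000 nM within 60000 nM to 400000 nM. The estimate amounts to a step that the limit leaves unreadable from compound 3 to compound 4, expected to be none beyond the scatter.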

Compound 4, half-maximal cytotoxic concentration: > 125000 nM
Compound 4 gave a limit, no number (the forecaster's own chance of this, stated with the estimate: 85%); the middle value does not contradict the limit.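

Among the compounds shown here, compound 4 also sits at a limit of this assay, so no step from compound 1, compound 2 or compound 3 to compound 4 can be read: the limit of > 125000 nM in this assay, at which 4 of the 4 values shown sit. The compounds shown leave open at what concentration any of these amides becomes cytotoxic.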